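Swapping an ethyl link for an ethoxy link

The compounds below may be only part of what the source reports. "The series", "measured", "known", "first", "only" and "open" are said of these compounds alone.

Compound 1 `N#Cc1ncc2nc1OCC/C=C\COc1ccc(O)cc1NC(=O)N2` – > 10000 nM
Compound 2 `N#Cc1ncc2nc1OCC/C=C\COc1ccc(CCOC3CCCCO3)cc1NC(=O)N2` – > 10000 nM

In a functional assay on NCI-H1299 cells (Homo sapiens), read by flow cytometry (a higher number here means that more compound is needed for the effect, a lower number that less compound is needed), compound 2 stands at > 10000 nM, which is a limit of the assay and not a number. Compound 1 gives > 10000 nM, also a limit. Among the compounds with values here, the whole record so far is the limit of > 10000 nM in this assay, at which 2 of the 2 values shown sit, so no compound has yet given a true number.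

Compound 3 `N#Cc1ncc2nc1OCC/C=C\COc1ccc(OCCOC3CCCCO3)cc1NC(=O)N2` differs from compound 2 in one place: 2-((oxan-2-yl)oxy)ethoxy in place of 2-((oxan-2-yl)oxy)ethyl on an aromatic carbon. In words, 2-((oxan-2-yl)oxy)ethoxy stands in place of 2-((oxan-2-yl)oxy)ethyl on an aromatic carbon.

Within the data shown here, the one measured step that bears on this change is a step that the two limits leave unreadable from compound 1 to compound 2. It concerns the same aromatic carbon, but it has no readable size to carry over. Among the measured compounds shown here, no step of a definite size or direction can therefore be expected in this assay, and the likeliest outcome is another reading at the limit. The estimated step is a step that the limit leaves unreadable from compound 2 to compound 3. For compound 3 the expected value is 12000 nM, with an estimated range from 4000 nM to 30000 nM.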

Compound 3, half-maximal effective concentration: > 10000 nM
Compound 3 was reported as a limit; the forecaster's own chance of this, stated with the estimate: 85%; the middle value is on the limit's open side.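

In this assay compound 3 gives > 10000 nM as a limit of the assay and not a number. No step can be read among compound 1, compound 2 and compound 3, and the record holds only one limit: the limit of > 10000 nM in this assay, at which 3 of the 3 values shown sit. The compounds shown leave open whether any group on this aromatic carbon gives a true number in this assay at all.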